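This account rests on a few compounds, and the source may have more. Where it says the series, first, only, none or still open, it means among the compounds named here.

The measurements come from an ADME assay on L929 cells (Mus musculus) for cytotoxicity, read by resazurin assay, with a stated time of 72 h (a higher number here means a weaker inhibitor, a lower number a stronger inhibitor), and three compounds built on one shared core have been run through it. Compound 1 `CC(=O)c1ccn(-c2ccc3c(c2)B(O)OC3)c1` carries a methyl on a carbonyl carbon. In this assay compound 1 gives > 10 ug/mL, which is a limit of the assay rather than a number. Compound 2 `O=C(c1ccccc1)c1ccn(-c2ccc3c(c2)B(O)OC3)c1` has a phenyl on that carbonyl carbon; in this assay compound 2 gives > 10 ug/mL, again a limit. Compound 3 `O=C(c1ccc(F)cc1)c1ccn(-c2ccc3c(c2)B(O)OC3)c1` carries a 4-fluorophenyl there, and in this assay compound 3 gives > 10 ug/mL, once more a limit. Because all three values sit at the limit of > 10 ug/mL in this assay, at which 3 of the 3 values shown sit, the steps a step that the two limits leave unreadable from compound 1 to compound 2, a step that the two limits leave unreadable from compound 1 to compound 3 and a step that the two limits leave unreadable from compound 2 to compound 3 cannot be read in size or direction; compound 3 therefore stands at the same limit as the two others, with no ranking possible among them.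

Compound 4 `O=C(c1cccc(Cl)c1)c1ccn(-c2ccc3c(c2)B(O)OC3)c1` is the next member. The change from compound 3 is 3-chlorophenyl in place of 4-fluorophenyl on a carbonyl carbon. Among the measured steps, the exchange of aromatic substituents from compound 2 to compound 3 is the nearest in kind, yet it is unreadable, so no size can be drawn from it. Given that every value so far rests at the limit, the step that the limit leaves unreadable from compound 3 to compound 4 is expected to stay within the scatter. Compound 4 is estimated at 15 ug/mL, with a range from 5 ug/mL to 50 ug/mL.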

Compound 4, half-maximal inhibitory concentration: > 10 ug/mL
Compound 4: only a limit was reported; the forecaster's own chance of this, stated with the estimate: 75%; the middle value lies beyond the limit too.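

In this assay compound 4 gives > 10 ug/mL, which is again a limit. The steps to compound 4 from compound 1, compound 2 and compound 3 therefore cannot be read in size or direction, because all four compounds share one result: the limit of > 10 ug/mL in this assay, at which 4 of the 4 values shown sit. The compounds shown leave open where each true value lies and whether changing the group on the carbonyl carbon affects cytotoxicity at all.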